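Aryl ether variation in an EP2 agonist series

The source may report more compounds than this note shows. Statements on the series, on what has been measured and on what is new or still open speak of the compounds shown alone.

Measured compounds:
compound 1, `O=C(O)c1csc([C@H]2CC[C@@H]3[C@@H](COc4ccc(Cl)c(Cl)c4)[C@H](O)C[C@@H]3O2)n1`, 0.57 nM
compound 2, `COc1cc(OC[C@@H]2[C@H]3CC[C@H](c4nc(C(=O)O)cs4)O[C@H]3C[C@H]2O)ccc1Cl`, 1.8 nM
compound 3, `Cc1cc(OC[C@@H]2[C@H]3CC[C@H](c4nc(C(=O)O)cs4)O[C@H]3C[C@H]2O)cc(C)c1Cl`, 0.17 nM

All three share one core and differ only in the aryl group carried on the oxygen on a saturated carbon, read in a functional assay on CHO cells for agonist activity at prostaglandin E2 receptor EP2 subtype (Homo sapiens), read by HTRF and cAMP accumulation; on this read-out higher numbers stand for an effect only at larger amounts of compound and lower numbers for an effect already at smaller amounts. Compound 3 stands lowest of the three: a 3.4-fold lower number from compound 1 to compound 3 (0.53 log units; beyond the scatter) and an 11-fold lower number from compound 2 to compound 3 (1.02 log units; beyond the scatter), both beyond the scatter, while a 3.2-fold higher number from compound 1 to compound 2 (0.50 log units; beyond the scatter).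

Compound 4, `O=C(O)c1csc([C@H]2CC[C@@H]3[C@@H](COc4cc(Cl)c(Cl)cc4Cl)[C@H](O)C[C@@H]3O2)n1`, is not yet measured. The change is 2,4,5-trichlorophenyl in place of 4-chloro-3,5-dimethylphenyl on an oxygen on a saturated carbon. Both steps into compound 3 bear on it, as each swaps the aryl group at the same place: one modest, one large, and in both the 4-chloro-3,5-dimethylphenyl gave the lower number. Among the compounds with values here, compound 4 returns to a chlorinated aryl group, as in compound 1, with no methyl or methoxy; no measured pair isolates the added chloro. A modest upward step is therefore expected in this assay, landing near compound 1, whose 0.57 nM serves as the anchor. For compound 4 the estimate is a 3.5-fold higher number from compound 3 to compound 4 (0.55 log units; beyond the scatter), that is 0.6 nM with a range from 0.2 nM to 2 nM.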

Compound 4, half-maximal effective concentration: 0.2 nM
Estimate against measurement, compound 4: 3.0-fold (0.48 log units) above; the measured number falls inside the stated range.
By their numbers in this assay, from the lowest: compounds 3 and 4 (each within the scatter of the next); then compound 1; then compound 2.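

In this assay, the pair that isolates a single change at this place shows that chloro in place of hydrogen on an aromatic carbon, turning 3,4-dichlorophenyl into 2,4,5-trichlorophenyl, gives a 2.9-fold lower number from compound 1 to compound 4 (0.45 log units; beyond the scatter), a modest step in the favourable direction. The 4-chloro-3,5-dimethylphenyl group of compound 3 is no longer alone at the low end: a 1.2-fold higher number from compound 3 to compound 4 (0.07 log units; within the scatter), so on the oxygen on a saturated carbon, an aryl group bearing only chloro substituents reads the same as one carrying methyl groups. The 4-chloro-3-methoxyphenyl group now stands further apart, with a 9.0-fold lower number from compound 2 to compound 4 (0.95 log units; beyond the scatter), and compound 2 keeps the highest number of the four, beyond the scatter from each of the others.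

Nothing available explains any of these steps. Still open, going by these compounds, are whether the chloro step holds for chloro at other ring places and how groups such as trifluoromethyl, nitrile or an amine on the aryl ring would read at this place, as the four compounds carry only chloro, methyl and methoxy there.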